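This account rests on a few compounds, and the source may have more. Where it says the series, first, only, none or still open, it means among the compounds named here.

Of the compounds shown here, three built on one shared core have been measured in an ADME assay on Vero cells (Chlorocebus sabaeus) for cytotoxicity, read by neutral red uptake, tested at 49 ug/mL; a lower number here means a stronger effect, a higher number a weaker effect of the compound at the concentration tested: compound 1 `O=C1CSC(c2ccc(Cl)cc2)N1CCN1CCCCC1`, compound 2 `O=C1CSC(c2ccc(F)cc2)N1CCN1CCCCC1` and compound 3 `COc1ccccc1C1SCC(=O)N1CCN1CCCCC1`. In this assay compound 2 gives 100%, compound 3 gives 100%, and compound 1 gives 84%. Compound 2 therefore stands level with compound 3 at the digits shown, the two together forming the highest of the three numbers, while compound 1 sits further off. Among the compounds with values here, the one single-point change measured so far, a number 16 percentage points higher from compound 1 to compound 2 (beyond the scatter), lies beyond the scatter but is modest in size.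

Compound 4 `Cc1ccc(C2SCC(=O)N2CCN2CCCCC2)cc1` is the next member awaiting a number in this assay. It differs from compound 2 by methyl in place of fluoro on an aromatic carbon. Within the data shown here, no measured step involves a methyl, so this change has no direct precedent in the set. The closest guide is the swap at the same aromatic carbon, a number 16 percentage points higher from compound 1 to compound 2 (beyond the scatter), which moved the number only modestly; on that basis a step of similar or smaller size, in either direction or none beyond the scatter, is expected. The step of a number 6 percentage points lower from compound 2 to compound 4 (within the scatter) is the expected outcome. Compound 4 is estimated at 94%, within a range from 78% to 106%.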

Compound 4, a percentage reported as activity, at one concentration (the size of the read-out at that concentration, not a potency): 100%
For compound 4 the middle estimate is 6 percentage points below the measured one, and the stated range covers the measured number.
By their numbers in this assay, from the lowest: compound 1; then compounds 2, 3 and 4 (each within the scatter of the next).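

In this assay, the step of no change at the digits printed from compound 2 to compound 4 (within the scatter) shows that this carbon, on a six-membered aromatic ring of carbon only and para to a large group, also takes a methyl, not only a halogen, with no shift from the number seen with fluoro. The step of a number 16 percentage points higher from compound 1 to compound 4 (beyond the scatter) matches the step of a number 16 percentage points higher from compound 1 to compound 2 (beyond the scatter) in size, so among the three groups compared at this carbon, chloro alone stands apart, while fluoro and methyl read alike; compound 1 is thus the only one of the three that gives a lower number. Nothing available explains why chloro differs from the other two groups here.

On these data alone, it remains open whether bromo would follow chloro, and whether a longer chain such as ethyl, an amine or a carboxylic acid on the same carbon would stay level with compound 2 and compound 4 or fall away from them. Each number also describes the size of the read-out at a single concentration, so how compound 1, compound 2 and compound 4 would compare at other concentrations cannot be told.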